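Solubility notes on the pyrazole propanamide series

The compounds below may be only part of what the source reports. "The series", "measured", "known", "first", "only" and "open" are said of these compounds alone.

Measured so far:
Compound 1, `CS(=O)(=O)NC(=O)CCc1cn(-c2ccc(Br)cc2)nc1-c1ccc(Cl)cc1`: 170000 nM
Compound 2, `CS(=O)(=O)NC(=O)CCc1cn(-c2ccc(Br)cc2)nc1C1CCOCC1`: 200000 nM

In a physicochemical assay for solubility, in phosphate buffer, measured as thermodynamic solubility, at pH 7.4 (on this read-out lower numbers stand for lower solubility and higher numbers for higher solubility), compound 2 stands highest of the two numbers recorded; its nearest neighbour is compound 1, and the step of a 1.2-fold higher number from compound 1 to compound 2 (0.07 log units; within the scatter) lies within the scatter, so the two values cannot be ordered.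

Compound 3, `CS(=O)(=O)NC(=O)CCc1cn(-c2ccc(Br)cc2)nc1-c1ccc([N+](=O)[O-])cc1`, has not yet been measured. It differs from compound 2 in one place: 4-nitrophenyl in place of oxan-4-yl on an aromatic carbon. Among the compounds with values here, the one measured step that bears on this exchange is a 1.2-fold higher number from compound 1 to compound 2 (0.07 log units; within the scatter), which swapped an aromatic six-membered ring for oxan-4-yl at the same aromatic carbon without moving the number beyond the scatter. The change to compound 3 runs the other way, from oxan-4-yl back to an aromatic ring, so no step beyond the scatter is expected in this assay. The step of a 1.3-fold lower number from compound 2 to compound 3 (0.12 log units; within the scatter) is therefore expected to be small. For compound 3 a value of 150000 nM is estimated, within 60000 nM to 320000 nM.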

Compound 3, solubility: < 5000 nM
Compound 3: no number, only a limit (the forecaster's own chance of this, stated with the estimate: 5%); middle value at least 30-fold (1.47 log units) away from the limit.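

In this assay compound 3 gives < 5000 nM as a limit of the assay and not a number. Even so, the group on this aromatic carbon, which made no readable difference between compound 1 and compound 2, now matters: the change to 4-nitrophenyl gives an at least 40-fold lower number from compound 2 to compound 3 (1.60 log units; beyond the scatter) and sits beyond the scatter. The sharper comparison is nitro in place of chloro on the phenyl ring, which gives an at least 34-fold lower number from compound 1 to compound 3 (1.53 log units; beyond the scatter) and shows that an aromatic ring at this place does not set the number by itself, since compound 1 stays within the scatter of compound 2.

From the compounds shown here alone, how far compound 3 lies past its limit stays unknown, so each step has a bound but no size. Also open, going by these compounds, is whether an amine or a carboxylic acid in place of the nitro would read like compound 1 or like compound 3.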